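One Carbon Less: Ethynyl to Methyl at the Carbamate

The source may report more compounds than this note shows. Statements on the series, on what has been measured and on what is new or still open speak of the compounds shown alone.

Four compounds built on one shared core were examined in a functional assay on MM1.S cells (Homo sapiens) for cytotoxicity, read by MTT assay, with a stated time of 48 h; on this read-out lower numbers stand for stronger inhibition and higher numbers for weaker inhibition. Compound 1 `O=C(NN=C1C(Cl)=C(Cl)C(Cl)=C1Cl)c1ccccc1` carries a benzoyl group, and in this assay compound 1 gives 800 nM. Compound 2 `CC(=O)NN=C1C(Cl)=C(Cl)C(Cl)=C1Cl` bears an acetyl group instead, and in this assay compound 2 gives "not determined" (no result reported), so no result was reported for it. Compound 3 `C#CC(C)(C)OC(=O)NN=C1C(Cl)=C(Cl)C(Cl)=C1Cl` is a carbamate, and in this assay compound 3 gives "not determined" (no result reported), so it also has no number; it stands alongside one further entry without a value. Compound 4 `CC(C)(C)OC(=O)NN=C1C(Cl)=C(Cl)C(Cl)=C1Cl` differs from compound 3 by methyl in place of ethynyl on a saturated chain carbon bound to an oxygen next to a carbonyl group and two saturated chain carbons. Going by the values given here, no measured step links the two carbamates, so the only anchor is compound 1, and a step beyond the scatter in either direction remains possible. Compound 4 is expected to give about 1500 nM in this assay, within a range from 300 nM to 8000 nM.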

Compound 4, half-maximal inhibitory concentration: 600 nM
Estimate against measurement, compound 4: 2.5-fold (0.40 log units) above; measured number inside the range.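

In this assay tert-butoxy in place of phenyl on a carbonyl carbon is a 1.3-fold lower number from compound 1 to compound 4 (0.12 log units; within the scatter) and so gives a carbamate that reads like the benzoyl compound. The position therefore tolerates this carbamate without a loss beyond the scatter. Nothing available bears on a cause for this.

Going by these compounds, the step from methyl back to ethynyl between compound 3 and compound 4 cannot be read, so the effect of the triple bond stays open. Also open, on these data alone, is how an amine or a longer chain would read on that carbonyl carbon.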